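The source may report more compounds than this note shows. Statements on the series, on what has been measured and on what is new or still open speak of the compounds shown alone.

In a physicochemical assay for solubility, in phosphate buffer, at pH 7.4 (on this read-out higher numbers stand for higher solubility and lower numbers for lower solubility), the measured compounds read as follows

Compound 1 (`OC1CCN(c2nccnc2OC2CN(c3ccc4ccccc4n3)C2)CC1`) gives 99000 nM
Compound 2 (`OC1CN(c2nccnc2OC2CN(c3ccc4ccccc4n3)C2)C1`) gives 41000 nM
Compound 3 (`NC(=O)C1CCN(c2nccnc2OC2CN(c3ccc4ccccc4n3)C2)CC1`) gives 14000 nM

Compound 3 has the lowest number of the three. Compound 4 (`c1ccc(-c2nccnc2OC2CN(c3ccc4ccccc4n3)C2)cc1`) differs from it. Compound 4 has phenyl in place of 4-carbamoylpiperidin-1-yl on an aromatic carbon. Three modest steps bear on this: a 2.4-fold lower number from compound 1 to compound 2 (0.38 log units; beyond the scatter) and a 2.9-fold lower number from compound 2 to compound 3 (0.47 log units; beyond the scatter) and a 7.1-fold lower number from compound 1 to compound 3 (0.85 log units; beyond the scatter) in this assay, all beyond the scatter. Each of them keeps a non-aromatic ring bearing hydroxy or carbamoyl, so none matches the phenyl change directly. A further fall, about as large as the biggest of these steps, is expected, and the estimated step is a 7.0-fold lower number from compound 3 to compound 4 (0.85 log units; beyond the scatter) as a rough guide. Compound 4 is estimated at 2000 nM with an expected range between 400 nM and 8000 nM around it.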

Compound 4, solubility: < 1000 nM
Compound 4 gave a limit, no number; the forecaster's own chance of this, stated with the estimate: 15%; middle value at least 2.0-fold (0.30 log units) away from the limit.
By their numbers in this assay, from the lowest: compound 3; then compound 2; then compound 1. At a limit, below all of these: compound 4.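

The reading for compound 4 in this assay is a limit, not a number: the limit of < 1000 nM in this assay, at which 1 of the 4 values shown sits. Phenyl on this aromatic carbon, next to the ring nitrogen, brings an at least 14-fold lower number from compound 3 to compound 4 (1.14 log units; beyond the scatter), an at least 41-fold lower number from compound 2 to compound 4 (1.61 log units; beyond the scatter) and an at least 99-fold lower number from compound 1 to compound 4 (1.99 log units; beyond the scatter), all large where the steps among the earlier compounds were modest. The hydroxy and carbamoyl rings thus sit together, well apart from phenyl at this position. From the compounds shown here alone, how far compound 4 lies past its limit remains open. So does whether an unsubstituted piperidin-1-yl or a pyridyl group would read nearer phenyl or those rings.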